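Three Methoxy Groups on a Shared Core

A few compounds are considered here, and "the series" means these few. Any claim that something is new, unique, unknown or untested is made for them only; others in the source may bear on it.

In a functional assay, with a stated time of 30 min, tested at 20 uM (on this read-out higher numbers stand for more inhibition at the one concentration tested (going by the name of the read-out) and lower numbers for less inhibition), compound 1 `c1ccc(-c2nnc(Nc3ncccn3)o2)cc1` gives 51.4%, compound 2 `COc1ccc(-c2nnc(Nc3ncccn3)o2)cc1` gives 45.8%, and compound 3 `COc1ccc(-c2nnc(Nc3ncccn3)o2)cc1OC` gives 49.5%. On these three numbers compound 3 lies within the scatter of both others, with compound 1 nearest. Compound 4 `COc1cc(-c2nnc(Nc3ncccn3)o2)cc(OC)c1OC` differs from compound 3 by methoxy in place of hydrogen on an aromatic carbon. Among the measured compounds shown here, two measured steps bear on this change, each itself a methoxy in place of hydrogen on an aromatic carbon: a number 5.6 percentage points lower from compound 1 to compound 2 (within the scatter) and a number 3.7 percentage points higher from compound 2 to compound 3 (within the scatter), both within the scatter. Because those steps stayed within the scatter, no step beyond it is expected here. The value of compound 4 in this assay is therefore estimated at 49%, within 36% to 62%. The expected step is a number 0.5 percentage points lower from compound 3 to compound 4 (within the scatter).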

Compound 4, a percentage reported as inhibition, at one concentration (the size of the read-out at that concentration, not a potency): 57.7%
Compound 4: the middle estimate sits 8.7 percentage points below what was measured; the range from low to high includes it.
By their numbers in this assay, from the lowest: compounds 2, 3, 1 and 4 (each within the scatter of the next, the first and the last beyond it).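

In this assay, a methoxy on this aromatic carbon, ortho to a methoxy group and meta to a large group, comes with a number 8.2 percentage points higher from compound 3 to compound 4 (within the scatter), so this position also takes the group without a step beyond the scatter. The opposite signs of the steps do not separate the two places where the change was read: the same change on two cores in this assay, a number 5.6 percentage points lower (within the scatter) from compound 1 to compound 2 and a number 8.2 percentage points higher (within the scatter) from compound 3 to compound 4, 13.8 percentage points apart, within the scatter of two such steps

The compounds shown leave open whether a different group at this position, such as an amine or a carboxylic acid, would move the inhibition beyond the scatter. A percentage at one concentration also gives no potency for any of them.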